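The source may report more compounds than this note shows. Statements on the series, on what has been measured and on what is new or still open speak of the compounds shown alone.

Among the measured compounds shown here, compound 1 `COc1cc(-c2cc(/C=C/C(=O)c3ccc(N)cc3)[nH]n2)cc(OC)c1OC` is one of two compounds measured so far in a functional assay on MOLT-4 cells (Homo sapiens) for inhibition, read by sulforhodamine B assay, with a stated time of 48 h; a higher number here means a weaker inhibitor of growth, a lower number a stronger inhibitor of growth; in this assay compound 1 gives 8510 nM. Compound 2 `COc1ccc(-c2cc(/C=C/C(=O)c3ccc(OC)c(OC)c3)[nH]n2)cc1` gives 8000 nM. Compound 1 carries the highest of the two numbers, yet its nearest neighbour, compound 2, stands within the usual scatter of it, so the two cannot be ordered. For the measured compounds named here, they also differ in more than one place, so no single-point step joins them.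

Compound 3 `COc1cc(-c2cc(/C=C/C(=O)c3ccc(Cl)c(Cl)c3)[nH]n2)cc(OC)c1OC` is not yet measured. It differs from compound 1 in one place: 3,4-dichlorophenyl in place of 4-aminophenyl on a carbonyl carbon. Going by the values given here, no measured pair carries this change, and the two numbers in hand give no direction for it. A modest step toward a stronger inhibitor of growth is expected, though it may well fall within the scatter; the expected step is a 1.7-fold lower number from compound 1 to compound 3 (0.23 log units; within the scatter). Compound 3 is expected to give 5000 nM, with a range from 1500 nM to 15000 nM.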

Compound 3, concentration for total growth inhibition: 40600 nM
Estimate against measurement, compound 3: 8.1-fold (0.91 log units) below; the measured number lies above the stated range.
By their numbers in this assay, from the lowest: compounds 2 and 1 (each within the scatter of the next); then compound 3.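

In this assay, among the compounds shown here, 3,4-dichlorophenyl in place of 4-aminophenyl on a carbonyl carbon gives a 4.8-fold higher number from compound 1 to compound 3 (0.68 log units; beyond the scatter), the first step that can be read at this position. The aryl group at this place therefore matters to growth inhibition, and this change runs toward a weaker inhibitor of growth. Nothing measured on these compounds explains the step.

A single pair cannot separate the loss of 4-aminophenyl from the arrival of 3,4-dichlorophenyl, and unsubstituted phenyl, 4-chlorophenyl or 4-(dimethylamino)phenyl at the same place would help to tell these apart. For the compounds shown here, whether the step holds on other cores also remains open, since compound 2 differs from the other compounds in more than one place and forms no step with them.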